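The source may hold more compounds than are shown below. What is called first, only, known or untested is meant among the compounds shown, and "the series" means these compounds.

Compound 1 `O=C1/C(=C/c2ccccc2F)CN(C(=S)SCc2cn(Cc3ccccc3Cl)nn2)C/C1=C\c1ccccc1F` and compound 2 `O=C1/C(=C/c2ccccc2F)CN(C(=S)SCc2cn(Cc3ccc(F)cc3)nn2)C/C1=C\c1ccccc1F` share one core; compound 3 `O=C1/C(=C/c2ccccc2F)CN(Cc2cn(Cc3ccccc3Cl)nn2)C/C1=C\c1ccccc1F` and compound 4 `O=C1/C(=C/c2ccccc2F)CN(Cc2cn(Cc3ccc(F)cc3)nn2)C/C1=C\c1ccccc1F` share another, and the difference between the two cores is not broken down here. In a functional assay on MDA-MB-231 cells (Homo sapiens) for cytotoxicity, read by MTT assay, with a stated time of 24 h (a higher number here means a weaker inhibitor, a lower number a stronger inhibitor), compound 1 gives 100000 nM, compound 2 gives 58800 nM and compound 3 gives 16500 nM. The change from compound 1 to compound 2 is 4-fluorophenyl in place of 2-chlorophenyl on a saturated chain carbon bound to an aromatic nitrogen, and it made a step of a 1.7-fold lower number from compound 1 to compound 2 (0.23 log units; within the scatter). The same change, (4-fluorophenyl in place of 2-chlorophenyl on a saturated chain carbon bound to an aromatic nitrogen), takes compound 3 to compound 4. Within this assay a step of about the same small size is expected, a 1.5-fold lower number from compound 3 to compound 4 (0.18 log units; within the scatter), because the only measured instance, a 1.7-fold lower number from compound 1 to compound 2 (0.23 log units; within the scatter), stayed within the scatter. Compound 4 is therefore estimated at 11000 nM, with the range 5000 nM to 30000 nM allowing for the scatter and for the change of core.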

Compound 4, half-maximal inhibitory concentration: 10000 nM
Beside the measured number, compound 4's estimate is 1.1-fold (0.04 log units) above it, and the stated range covers the measured number.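

In this assay, replacing 2-chlorobenzyl with 4-fluorobenzyl gives a 1.7-fold lower number from compound 3 to compound 4 (0.22 log units; within the scatter) and matches the step on the other core: the same change on two cores in this assay, a 1.7-fold lower number (0.23 log units; within the scatter) from compound 1 to compound 2 and a 1.7-fold lower number (0.22 log units; within the scatter) from compound 3 to compound 4, 1.0-fold (0.01 log units) apart, within the scatter of two such steps. The change therefore stays small on both cores, but with both steps within the scatter, neither shows that the change itself moves the number. One pair of groups on two cores shows nothing about other cores or about other changes at this place.

Still open, from the compounds shown here alone, is how groups of another kind would behave on a saturated chain carbon bound to an aromatic nitrogen, such as a benzyl carrying an amine or a carboxylic acid, or a longer chain in place of the benzyl. Going by these compounds, the separate contribution of the difference between the two cores also remains open.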